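The compounds below may be only part of what the source reports. "The series", "measured", "known", "first", "only" and "open" are said of these compounds alone.

Measured in a functional assay on SK-BR-3 cells (Homo sapiens) for antiproliferative activity, read by MTT assay, with a stated time of 72 h; on this read-out higher numbers stand for weaker inhibition and lower numbers for stronger inhibition:

- compound 1 `C/C=C1/[C@H](O[C@@H]2O[C@H](CO)[C@@H](O)[C@H](O)[C@H]2O)OC=C(C(=O)OC)[C@H]1CC(=O)OCCCc1ccc(OC)c(OC)c1`: > 20000 nM
- compound 2 `C/C=C1/[C@H](O[C@@H]2O[C@H](COC(C)=O)[C@@H](OC(C)=O)[C@H](OC(C)=O)[C@H]2OC(C)=O)OC=C(C(=O)OC)[C@H]1CC(=O)OCCC(C)C`: > 15000 nM
- compound 3 `C/C=C1/[C@H](O[C@@H]2O[C@H](COC(C)=O)[C@@H](OC(C)=O)[C@H](OC(C)=O)[C@H]2OC(C)=O)OC=C(C(=O)OC)[C@H]1CC(=O)SCCC`: > 15000 nM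

Compound 1 gives > 20000 nM, and this is a limit of the assay, not a number. Compounds 2 and 3 offer no number either. The picture so far is the limit of > 15000 nM in this assay, at which 2 of the 3 values shown sit, together with the limit of > 20000 nM in this assay, at which 1 of the 3 values shown sits. Every measured compound therefore sits at a limit, and no true potency is available as a reference point.

Compound 4 `C/C=C1/[C@H](O[C@@H]2O[C@H](CO)[C@@H](O)[C@H](O)[C@H]2O)OC=C(C(=O)OC)[C@H]1CC(=O)OCCc1ccc(O)c(O)c1` keeps the core of compound 1 and changes one end of the molecule: 3,4-dihydroxyphenyl in place of 3,4-dimethoxybenzyl on a saturated chain carbon, two bonds along the chain from an oxygen next to a carbonyl group. The swap lies on a saturated chain carbon, two bonds along the chain from an oxygen next to a carbonyl group.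

Within the data shown here, the only measured step is a step that the two limits leave unreadable from compound 2 to compound 3. It concerns a different change on a different pair and has no readable size, so it offers no guide here. The expectation instead rests on compound 1 at > 20000 nM, the nearest structure. No change beyond the scatter is expected, and compound 4 will quite likely return only a limit as well.

The expected result is a step that the limit leaves unreadable from compound 1 to compound 4. For compound 4 the estimate is 25000 nM, with an expected range of 10000 nM to 60000 nM.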

Compound 4, half-maximal inhibitory concentration: 160000 nM
For compound 4 the middle estimate is 6.4-fold (0.81 log units) below the measured one; measured number outside the range, above it.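

The value of compound 1, > 20000 nM, is a limit and not a number. Compound 4 gives 160000 nM, but the size of the step between compound 1 and compound 4 cannot be read. The compounds shown leave open how much 3,4-dihydroxyphenyl in place of 3,4-dimethoxybenzyl changes inhibition, and whether any related structure inhibits strongly.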